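One methyl fewer: from compound 2 to compound 3

The compounds below may be only part of what the source reports. "The series", "measured", "known", "first", "only" and "open" are said of these compounds alone.

Compound 1 `Cc1cccc(-c2cccc(NCc3cncn3Cc3ccccc3)c2)c1C` and compound 2 `Cc1cccc(-c2cccc(NCc3cncn3Cc3ccccc3)c2)c1` have both been tested in a toxicity assay on NIH3T3 cells (Mus musculus) for cytotoxicity, read by resazurin assay (on this read-out lower numbers stand for an effect already at smaller amounts and higher numbers for an effect only at larger amounts of compound), so far. Compound 1 gives > 1000 nM as a limit and not as a number. Compound 2 gives > 1000 nM as a limit too. Compound 2 therefore stands only at the limit of > 1000 nM in this assay, at which 2 of the 2 values shown sit, and has no exact value to start from.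

Compound 3 `c1ccc(Cn2cncc2CNc2cccc(-c3ccccc3)c2)cc1` has not yet been measured. It differs from compound 2 by hydrogen in place of methyl on an aromatic carbon and the change is hydrogen in place of methyl on an aromatic carbon, so that 3-methylphenyl becomes phenyl. Within the data shown here, the one measured change of this kind is a step that the two limits leave unreadable from compound 1 to compound 2 and so it offers no size to carry over.

With no readable size to go on, no step beyond the usual scatter is expected in this assay and no direction is favoured. The expected step is a step that the limit leaves unreadable from compound 2 to compound 3 on this estimate. For compound 3 the estimate is 2000 nM with an expected range from 1000 nM to 10000 nM and this assay may well report only a limit again.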

Compound 3, half-maximal effective concentration: > 750 nM
Compound 3 was reported as a limit (the forecaster's own chance of this, stated with the estimate: 85%); the middle value does not contradict the limit.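

No step can be read among compound 1, compound 2 and compound 3: in this assay each is reported only as a limit, not as a number. The compounds shown leave open whether hydrogen in place of methyl changes the effect on these cells at all, and at what concentration any of the three has an effect.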